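A few compounds are considered here, and "the series" means these few. Any claim that something is new, unique, unknown or untested is made for them only; others in the source may bear on it.

Compound 3 `O=C(Nc1ccccc1Br)N[C@@H]1CCN(c2ccccn2)C1` carries a pyridin-2-yl group on the ring nitrogen of its five-membered core. In a functional assay for antagonist activity at transient receptor potential cation channel subfamily V member 1 (Rattus norvegicus), read by FLIPR (a higher number here means a more potent compound, by a factor of ten per unit of this negative logarithm, a lower number a less potent compound), compound 3 gives < 6.6, which is a limit of the assay and not a number. Two close relatives vary that pyridine. Compound 1 `O=C(Nc1ccccc1Br)N[C@@H]1CCN(c2ccc(Cl)cn2)C1` bears a chloro on it, and in this assay compound 1 gives 7.3. Compound 2 `Cc1ccc(N2CC[C@@H](NC(=O)Nc3ccccc3Br)C2)nc1` bears a methyl there instead. In this assay compound 2 gives < 6.7, again a limit. The step of a number at least 0.70 log units lower from compound 1 to compound 3 (beyond the scatter) and the step of a number at least 0.60 log units lower from compound 1 to compound 2 (beyond the scatter) were both at least modest losses, while a step that the two limits leave unreadable from compound 2 to compound 3 cannot be sized because the limit of < 6.6 in this assay, at which 1 of the 3 values shown sits, and the limit of < 6.7 in this assay, at which 1 of the 3 values shown sits, hold no numbers.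

Compound 4 `Cc1ccc(N2CC[C@@H](NC(=O)Nc3ccccc3Br)C2)cc1F` differs from compound 3 by 3-fluoro-4-methylphenyl in place of pyridin-2-yl on an amine nitrogen in a ring. Within the data shown here, none of the measured steps exchanges the whole aromatic ring; they only change one substituent on the pyridine, so they give no direct guide to this change, and its direction is open. Compound 4 is therefore expected to give about 6.8, within 6 to 7.6. That expectation amounts to a step of a number at least 0.20 log units higher from compound 3 to compound 4 (that floor lies within the scatter) in this assay.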

Compound 4, negative logarithm of the antagonist equilibrium constant: 8.3
Compound 4: the middle estimate sits 1.50 log units below what was measured; the whole stated range lies below it.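

The earlier compounds changed only one substituent on the pyridine, whereas exchanging the whole aromatic ring on the ring nitrogen of the core shows that a carbon-only ring can outperform even the best pyridine shown in this assay, with a number 1.00 log units higher from compound 1 to compound 4 (beyond the scatter). The step of a number at least 1.70 log units higher from compound 3 to compound 4 (beyond the scatter) starts from a limit, so it gives only a floor on the size of the gain: the limit of < 6.6 in this assay, at which 1 of the 4 values shown sits. The step of a number at least 1.60 log units higher from compound 2 to compound 4 (beyond the scatter) likewise starts from a limit and gives only a floor: the limit of < 6.7 in this assay, at which 1 of the 4 values shown sits.

Compound 4 changes the ring and adds both the fluoro and the methyl, so the compounds shown cannot say which of these carries the gain. An unsubstituted phenyl, or a phenyl bearing only the fluoro or only the methyl, would separate these contributions.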